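A few compounds are considered here, and "the series" means these few. Any claim that something is new, unique, unknown or untested is made for them only; others in the source may bear on it.

Compound 1 `COc1ccccc1NC(=O)N[C@H]1CC[C@H](Oc2ccc(F)cc2)CC1` is the starting point. In a functional assay on CRL2813 cells (Homo sapiens) for cytotoxicity, read by sulforhodamine B assay, with a stated time of 5 days (a lower number here means a stronger inhibitor, a higher number a weaker inhibitor), compound 1 gives only a limit, > 20000 nM; it stands at the limit of > 20000 nM in this assay, at which 2 of the 3 values shown sit. Compound 2 `O=C(Nc1ccccc1C(=O)O)N[C@H]1CC[C@@H](Oc2ccc(F)cc2)CC1` in this assay also gives only a limit, > 20000 nM. Going by the values given here, compound 3 `O=C(Nc1ccccc1Br)N[C@H]1CC[C@H](Oc2ccc(F)cc2)CC1` in this assay gives 7700 nM, the one numerical value in the set. Among the compounds with values here, the single measured step, an at least 2.5-fold lower number from compound 1 to compound 3 (0.41 log units; beyond the scatter), moves the number off the limit.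

Compound 4 `COc1cccc(NC(=O)N[C@H]2CC[C@H](Oc3ccc(F)cc3)CC2)c1` differs from compound 1 by 3-methoxyphenyl in place of 2-methoxyphenyl on an amide-type nitrogen. Within the data shown here, no measured step moves the methoxy group to another position on its ring; the step from compound 1 to compound 3 exchanges the group instead. It therefore bears on compound 4 only loosely, as a sign that a single change at this ring can shift the number by a modest amount. With compound 1 at the limit, the expected outcome for compound 4 is a value close to that limit, and the step expected is a number no higher from compound 1 to compound 4 (the limit leaves the size open), not beyond the scatter. Compound 4 is expected at 20000 nM, within 8000 nM to 50000 nM.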

Compound 4, half-maximal inhibitory concentration: 14000 nM
The estimate for compound 4 lay 1.4-fold (0.15 log units) above the measured number, within the range that was stated.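

In this assay, 3-methoxyphenyl in place of 2-methoxyphenyl on the amide-type nitrogen gives a number rather than a limit, yet the change reads only as an at least 1.4-fold lower number from compound 1 to compound 4 (0.15 log units; that floor lies within the scatter). Compound 1 stands at a limit, and the true size of this step stays open for that reason: the limit of > 20000 nM in this assay, at which 2 of the 4 values shown sit.
Also new is that 3-methoxyphenyl and 2-bromophenyl are not told apart at this place, the comparison giving a 1.8-fold higher number from compound 3 to compound 4 (0.26 log units; within the scatter).

Open, from the compounds shown here alone, is how an amine or a nitrile on this ring would read in this assay. Also open, going by these compounds, is whether any single change at this ring can move the number beyond the scatter from compound 3.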